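Trifluoromethyl to methyl at the limit of detection

A few compounds are considered here, and "the series" means these few. Any claim that something is new, unique, unknown or untested is made for them only; others in the source may bear on it.

In a functional assay on HCT-15 cells (Homo sapiens) for cytotoxicity, read by MTT assay, with a stated time of 2 days (a higher number here means a weaker inhibitor, a lower number a stronger inhibitor), compound 1 `Cc1ccc2nc(-c3ccccc3N(C)C)[nH]c(=O)c2c1` gives > 50000 nM, which is a limit and not a number. Compound 2 `Cc1ccc2nc(-c3ccccc3C(F)(F)F)[nH]c(=O)c2c1` gives > 50000 nM, which is also only a limit. Compound 2 therefore has no exact potency to start from, and the evidence so far is the limit of > 50000 nM in this assay, at which 2 of the 2 values shown sit. Within the data shown here, the one measured comparison is a step that the two limits leave unreadable from compound 1 to compound 2, so it offers no size to carry forward.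

Compound 3 `Cc1ccc2nc(-c3ccccc3C)[nH]c(=O)c2c1`, not yet measured, differs from compound 2 by one swap on an aromatic carbon: methyl in place of trifluoromethyl on an aromatic carbon. Because of the limit of > 50000 nM in this assay, at which 2 of the 2 values shown sit, no step beyond the scatter is expected in this assay, in either direction. The estimated outcome is a number no higher from compound 2 to compound 3 (the limit leaves the size open). For compound 3 the expected half-maximal inhibitory concentration is about 50000 nM, with an estimated range of 25000 nM to 100000 nM.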

Compound 3, half-maximal inhibitory concentration: 11700 nM
Compound 3: middle estimate off by 4.3-fold (0.63 log units), on the high side, outside the stated range (below it).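

Among these compounds, at this position on the ring, the choice of group can move the result off the limit of the assay: in this assay, the change to methyl gives an at least 4.2-fold lower number from compound 2 to compound 3 (0.63 log units; beyond the scatter), and compound 3 gives the first exact value. Methyl in place of dimethylamino gives the same kind of result, an at least 4.2-fold lower number from compound 1 to compound 3 (0.63 log units; beyond the scatter), so of the three groups shown, only methyl gives a readable value. Both steps are minimum sizes and not full ones, because each starts from a compound that has only a limit: the limit of > 50000 nM in this assay, at which 2 of the 3 values shown sit.

The compounds shown leave open how large either step really is. They also leave open whether something specific to methyl matters here, which an ethyl chain, a methoxy group or a chlorine atom on this carbon could begin to test.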